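Methoxy in Place of Cyano: Expectations for Compound 4

This account rests on a few compounds, and the source may have more. Where it says the series, first, only, none or still open, it means among the compounds named here.

The measured compounds:
compound 1 `c1cncc(N2C[C@@H]3CCNC[C@@H]32)c1`, 1700 nM
compound 2 `COc1cc(N2C[C@@H]3CCNC[C@@H]32)cnc1Br`, 2980 nM
compound 3 `N#Cc1cncc(N2C[C@@H]3CCNC[C@@H]32)c1`, 2560 nM

All three share the same core and differ only in the groups on the aromatic ring. In a functional assay on HEK293 cells for agonist activity at Neuronal acetylcholine receptor; alpha3/beta4 (Homo sapiens), read by FLIPR (on this read-out lower numbers stand for an effect already at smaller amounts and higher numbers for an effect only at larger amounts of compound), compound 3 gives 2560 nM, the second highest of the three numbers. Its nearest neighbour is compound 2 with 2980 nM, and its furthest is compound 1 with 1700 nM; both lie within the scatter of compound 3. Compound 4 `COc1cncc(N2C[C@@H]3CCNC[C@@H]32)c1` differs from compound 3 by methoxy in place of cyano on an aromatic carbon. For the measured compounds named here, the one measured step that bears on this change is a 1.5-fold higher number from compound 1 to compound 3 (0.18 log units; within the scatter), where a cyano replaced a hydrogen on an aromatic carbon. Compound 2 also carries a methoxy, but together with a bromine, so it offers no single-change comparison. Going by the values given here, with the only relevant step within the scatter, no step beyond the scatter is expected in this assay. Compound 4 is therefore expected to give about 2200 nM, ranging from 900 nM to 5000 nM. The expected step is a 1.2-fold lower number from compound 3 to compound 4 (0.07 log units; within the scatter), within the scatter.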

Compound 4, half-maximal effective concentration: 63500 nM
Compound 4: middle estimate off by 29-fold (1.46 log units), on the low side; the whole stated range lies below it.
By their numbers in this assay, from the lowest: compounds 1, 3 and 2 (each within the scatter of the next); then compound 4.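

In this assay, methoxy in place of cyano brings a 25-fold higher number from compound 3 to compound 4 (1.39 log units; beyond the scatter), although the two groups match in their counts of heavy atoms and hydrogen-bond acceptors, so those counts do not predict the outcome at this position. Methoxy in place of hydrogen brings a 37-fold higher number from compound 1 to compound 4 (1.57 log units; beyond the scatter), while cyano in place of hydrogen stayed within the scatter, so the identity of the group on this aromatic carbon matters greatly. Compound 2 carries a methoxy as well as a bromo, and hydrogen in place of bromo brings a 21-fold higher number from compound 2 to compound 4 (1.33 log units; beyond the scatter), so the high number of compound 4 does not appear when bromo is also present.

No measurement here explains these jumps. From the compounds shown here alone, whether an amine, an ethoxy or a lone bromo at this position would behave like cyano or like methoxy remains open.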